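The source may report more compounds than this note shows. Statements on the series, on what has been measured and on what is new or still open speak of the compounds shown alone.

Measured so far:
compound 1, `CCCCc1cc(CC)c(O)cc1OCCCCCC(C)(C)c1nnn[nH]1`, 8700 nM in an assay on isolated protein for antagonist activity at Bile acid receptor (Homo sapiens), read by HTRF, with a stated time of 30 min; a lower number here means a stronger inhibitor, a higher number a weaker inhibitor 
compound 2, `CCc1cc(C(=O)C(C)C)c(O)cc1OCCCCCC(C)(C)c1nnn[nH]1`, 8600 nM in this assay 

Both compounds share the same core and differ only in the groups on the phenol ring. In this assay compound 2 gives 8600 nM, and compound 1 gives 8700 nM, and these two numbers lie within the scatter of each other, so neither can be called stronger or weaker.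

Compound 3, `CCc1cc(C(=O)c2ccccc2)c(O)cc1OCCCCCC(C)(C)c1nnn[nH]1`, has not yet been measured. It differs from compound 2 in one place: phenyl in place of isopropyl on a carbonyl carbon. Going by the values given here, no step between two measured compounds of this kind is available, so the direction of the change rests on no direct precedent. Compound 3 is estimated at 6000 nM, with a range from 1500 nM to 25000 nM. The step of a 1.4-fold lower number from compound 2 to compound 3 (0.16 log units; within the scatter) is expected to be small, likely not far beyond the scatter.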

Compound 3, half-maximal inhibitory concentration: 3100 nM
The estimate for compound 3 lay 1.9-fold (0.29 log units) above the measured number, within the range that was stated.
By their numbers in this assay, from the lowest: compound 3; then compounds 2 and 1 (each within the scatter of the next).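

Compounds 1 and 2 differ in the groups on the phenol ring, and their values lie within the scatter of each other, so they could not show whether the group on the carbonyl carbon matters. Replacing isopropyl with phenyl at this place gives a 2.8-fold lower number from compound 2 to compound 3 (0.44 log units; beyond the scatter) in this assay, a modest step but the first one beyond the scatter, so what sits on this carbonyl carbon does change the reading. No measurement shown here explains why the number moves in this direction.

This single change swaps three carbons without a ring for six carbons in an aromatic ring, so it cannot separate the effect of the ring from that of the carbon count. A cyclohexyl group or a longer chain on the same carbonyl carbon would bear on that question.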